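Methoxy to Hydroxy on the Shared Core: Expected Binding

The compounds below may be only part of what the source reports. "The series", "measured", "known", "first", "only" and "open" are said of these compounds alone.

Measured compounds:
Compound 1 `CCCS(=O)(=O)Nc1ccc(F)c(C(=O)c2n[nH]c3ncc(-c4ccccc4Cl)cc23)c1F`: 9.3%
Compound 2 `CCCS(=O)(=O)Nc1ccc(F)c(C(=O)c2n[nH]c3ncc(-c4cccc(F)c4)cc23)c1F`: 8.2%
Compound 3 `CCCS(=O)(=O)Nc1ccc(F)c(C(=O)c2n[nH]c3ncc(-c4ccc(OC)cc4)cc23)c1F`: 4.2%

These three compounds were tested in an assay for binding affinity to dual specificity mitogen-activated protein kinase kinase 4 (Homo sapiens), read by KINOMEscan, tested at 100 nM; on this read-out lower numbers stand for a stronger effect and higher numbers for a weaker effect at the one concentration tested. Compound 3 gives the lowest of the three numbers, but its gap to compound 2, a number 4 percentage points lower from compound 2 to compound 3 (within the scatter), and to compound 1, a number 5.1 percentage points lower from compound 1 to compound 3 (within the scatter), are both within the scatter, so no order among them can be claimed. Compound 4 `CCCS(=O)(=O)Nc1ccc(F)c(C(=O)c2n[nH]c3ncc(-c4ccc(O)cc4)cc23)c1F` is not yet measured. It differs from compound 3 by hydrogen in place of methyl on an oxygen on an aromatic ring. Among the compounds with values here, none of the measured steps touches this oxygen, so no step bears directly on it; the steps that exist, a number 1.1 percentage points lower from compound 1 to compound 2 (within the scatter) and a number 5.1 percentage points lower from compound 1 to compound 3 (within the scatter), were all small. For compound 4 a step of a number 1.8 percentage points higher from compound 3 to compound 4 (within the scatter) in this assay is therefore expected, nothing beyond the scatter. Compound 4 is estimated at 6%, within 1% to 16%.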

Compound 4, a percentage reported as activity, at one concentration (the size of the read-out at that concentration, not a potency): 0.75%
Compound 4: middle estimate off by 5.3 percentage points, on the high side; measured number below the stated range.
By their numbers in this assay, from the lowest: compounds 4, 3, 2 and 1 (each within the scatter of the next).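

In this assay, within the data shown here, the oxygen itself is changed for the first time: hydrogen in place of methyl gives a number 3.5 percentage points lower from compound 3 to compound 4 (within the scatter) and so does not separate methoxy from hydroxy. Replacing the whole group shows the same, with a number 7.5 percentage points lower from compound 2 to compound 4 (within the scatter) and a number 8.6 percentage points lower from compound 1 to compound 4 (within the scatter) and all four compounds remaining within the scatter of one another at this single concentration. Nothing available explains these small steps.

On these data alone, it remains open whether an amine or a carboxylic acid in place of the hydroxy would give a step beyond the scatter.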